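The compounds below may be only part of what the source reports. "The series", "measured", "known", "first", "only" and "open" are said of these compounds alone.

Measured in an ADME assay on SK-OV-3 cells (Homo sapiens) for cytotoxicity, read by neutral red uptake, with a stated time of 48 h; on this read-out lower numbers stand for stronger inhibition and higher numbers for weaker inhibition:

Compound 1 `O=c1sc2ccccc2n1CCCCCN1CCN(CCCCCn2c(=O)sc3ccccc32)CC1`: 25000 nM
Compound 2 `O=c1sc2ccccc2n1CCCCCCN1CCN(CCCCCCn2c(=O)sc3ccccc32)CC1`: 24300 nM

Compound 2, at 24300 nM, stands level with compound 1, at 25000 nM; the two values lie within the scatter of each other. Compound 3 `O=c1sc2ccccc2n1CCCCCCN1CCN(CCCCCn2c(=O)sc3ccccc32)CC1` is the next to be read. It differs from compound 2 as follows: a group of 10 heavy atoms (7 carbon, 1 nitrogen, 1 oxygen, 1 sulfur; one five-membered aromatic ring with 2 hetero atoms, one six-membered aromatic ring of carbon only) in place of a group of 11 heavy atoms (8 carbon, 1 nitrogen, 1 oxygen, 1 sulfur; one five-membered aromatic ring with 2 hetero atoms, one six-membered aromatic ring of carbon only), on a saturated chain carbon, five bonds along the chain from an amine nitrogen in a ring. The exchange falls on a saturated chain carbon, five bonds along the chain from an amine nitrogen in a ring. Among the compounds with values here, no measured step is available. The structure of compound 3 mixes those of compound 1 and compound 2, so no step beyond the scatter is expected in this assay. The estimate means a 1.0-fold lower number from compound 2 to compound 3 (0.01 log units; within the scatter), an expected change within the scatter. For compound 3 the expected value is 24000 nM, with an estimated range of 12000 nM to 45000 nM.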

Compound 3, half-maximal inhibitory concentration: 25000 nM
Compound 3: middle estimate off by 1.0-fold (0.02 log units), on the low side; the measured number falls inside the stated range.
By their numbers in this assay, from the lowest: compounds 2, 1 and 3 (each within the scatter of the next).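

In this assay the step of a 1.0-fold higher number from compound 2 to compound 3 (0.01 log units; within the scatter) comes from a group of 10 heavy atoms in place of a group of 11 heavy atoms, on a saturated chain carbon, five bonds along the chain from an amine nitrogen in a ring. The opposite exchange at that place gives no change at the digits printed from compound 1 to compound 3 (within the scatter) and completes the set: the compound with two unequal chains reads level with both compounds with equal chains, so this exchange does not move the number in either direction. No supporting measurement bears on this result, and it offers no explanation for it.

Still open, on these data alone, is whether a longer chain or a much shorter chain on either side of the ring amine would read differently in this assay and give a step beyond the scatter. Also open, as far as these compounds go, is what an amine or a carboxylic acid would do in place of either end group.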